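Chloro for methoxy on the aryl ring of compound 1

The compounds below may be only part of what the source reports. "The series", "measured", "known", "first", "only" and "open" are said of these compounds alone.

Compound 1 `CCCN(c1nccc(-c2c(OC)cc(OC)cc2OC)n1)C(C1CC1)C1CC1` gives the lower of the two numbers in an assay on CHO cells for displacement of a labelled ligand from corticotropin-releasing factor receptor 1 (Homo sapiens) (a lower number here means a stronger inhibitor, a higher number a weaker inhibitor), namely 15 nM. Among the compounds with values here, compound 2 `CCCN(c1nccc(-c2c(OC)cc(OC)cc2OC)n1)C1CCCC1` gives 2200 nM in this assay, and the only measured step, a 150-fold higher number from compound 1 to compound 2 (2.17 log units; beyond the scatter), concerns the group on the nitrogen. Compound 3 `CCCN(c1nccc(-c2c(Cl)cc(OC)cc2OC)n1)C(C1CC1)C1CC1` differs from compound 1 elsewhere: chloro in place of methoxy on an aromatic carbon, on the six-membered aromatic ring of carbon only. Within the data shown here, no measured step touches that ring, so the account expects for compound 3 a step of a 1.5-fold lower number from compound 1 to compound 3 (0.18 log units; within the scatter), within the scatter. Compound 3 is estimated at 10 nM, between 2 nM and 50 nM.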

Compound 3, inhibition constant: 11 nM
Beside the measured number, compound 3's estimate is 1.1-fold (0.04 log units) below it, within the range that was stated.
By their numbers in this assay, from the lowest: compounds 3 and 1 (each within the scatter of the next); then compound 2.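

In this assay, chloro in place of methoxy on an aromatic carbon, ortho to a large group, gives a 1.4-fold lower number from compound 1 to compound 3 (0.13 log units; within the scatter). Compound 3 therefore cannot be told apart from compound 1 in this assay, so this methoxy group, with its oxygen, is not required at this position in the dicyclopropylmethyl series. The compounds shown leave open what an amine or a carboxylic acid would do at this position, and whether either of the two remaining methoxy groups can be exchanged for chloro in the same way. No measurement shown here accounts for this result.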